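The source may report more compounds than this note shows. Statements on the series, on what has been measured and on what is new or still open speak of the compounds shown alone.

In an ADME assay on NIH3T3 cells (Mus musculus) for cytotoxicity, read by MTT assay, with a stated time of 72 h (on this read-out lower numbers stand for stronger inhibition and higher numbers for weaker inhibition), compound 1 `COc1ccc(/C=C/C(=O)CC(C)=O)cc1OC` gives 18100 nM and compound 2 `COc1ccc(/C=C/C(=O)CC(C)=O)cc1` gives 48200 nM as the higher of the two numbers. Compound 3 `CC(=O)CC(=O)/C=C/c1ccc(O)cc1` differs from compound 2 by one change, hydrogen in place of methyl on an oxygen on an aromatic ring with hydrogen in place of methyl on an oxygen on an aromatic ring. Going by the values given here, the only measured step, a 2.7-fold higher number from compound 1 to compound 2 (0.43 log units; beyond the scatter) for hydrogen in place of methoxy on an aromatic carbon, is modest and a loose guide, since the oxygen stays here. In this assay a similarly modest move toward a lower number is expected, and the estimated step is a 1.6-fold lower number from compound 2 to compound 3 (0.21 log units; within the scatter). Compound 3 is expected at 30000 nM, within a range from 11000 nM to 80000 nM.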

Compound 3, half-maximal inhibitory concentration: 18900 nM
Compound 3: middle estimate off by 1.6-fold (0.20 log units), on the high side, within the range that was stated.
By their numbers in this assay, from the lowest: compounds 1 and 3 (each within the scatter of the next); then compound 2.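

Taking away only the methyl and keeping the oxygen on the aromatic ring gives a 2.6-fold lower number from compound 2 to compound 3 (0.41 log units; beyond the scatter) in this assay. So the methyl on this oxygen counts by itself, and the number moves the opposite way to a 2.7-fold higher number from compound 1 to compound 2 (0.43 log units; beyond the scatter), where a whole methoxy was lost, oxygen included. What the compounds shown leave open is how a longer chain such as ethoxy on this oxygen, or an amine in place of the hydroxy, would read. Nothing measured here gives a reason for either step.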